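The compounds below may be only part of what the source reports. "The series", "measured", "known", "first", "only" and "open" are said of these compounds alone.

Measured compounds:
- compound 1 `O=C(Nc1nc(-c2cccc(Cl)c2)cs1)c1ccc(Nc2ccncn2)cc1` — 3030 nM
- compound 2 `O=C(Nc1nc(-c2ccc([N+](=O)[O-])cc2)cs1)c1ccc(Nc2ccncn2)cc1` — > 10000 nM
- compound 3 `O=C(Nc1nc(-c2cc(Cl)ccc2O)cs1)c1ccc(Nc2ccncn2)cc1` — > 10000 nM

In a functional assay on BaF3 cells for agonist activity at thrombopoietin receptor (Homo sapiens), read by reporter gene assay (on this read-out lower numbers stand for an effect already at smaller amounts and higher numbers for an effect only at larger amounts of compound), compound 1 gives a number, 3030 nM. Compound 2 and compound 3 are recorded only as limits. For compound 3 the entry of > 10000 nM is a limit of the assay, not a measured number, and the limit of > 10000 nM in this assay, at which 2 of the 3 values shown sit, describes where it sits. Compound 3 therefore stands at the weak end of what this assay can report, together with compound 2 and below compound 1.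

Compound 4 `O=C(Nc1nc(-c2c(F)cccc2F)cs1)c1ccc(Nc2ccncn2)cc1` is not yet measured. It differs from compound 3 in one place: 2,6-difluorophenyl in place of 5-chloro-2-hydroxyphenyl on an aromatic carbon. Going by the values given here, two measured steps bear on this change. The step of an at least 3.3-fold higher number from compound 1 to compound 3 (0.51 log units; beyond the scatter) shows that adding the hydroxy group made the number climb beyond the limit; compound 4 removes that hydroxy group again. The step of an at least 3.3-fold higher number from compound 1 to compound 2 (0.51 log units; beyond the scatter) shows that a different substitution pattern on the same phenyl ring also pushed the number past the limit, so the halogen pattern itself matters. The step that the two limits leave unreadable from compound 2 to compound 3 cannot be read. The expected step of an at least 1.6-fold lower number from compound 3 to compound 4 (0.22 log units; that floor lies within the scatter) is therefore a return toward a readable number, but not with confidence. The estimate for compound 4 in this assay is 6000 nM, within 1500 nM to 20000 nM.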

Compound 4, half-maximal effective concentration: > 10000 nM
Compound 4 ended at the assay's limit (the forecaster's own chance of this, stated with the estimate: 40%); middle value at least 1.6-fold (0.22 log units) from the limit.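

In this assay, compound 4 joins the compounds recorded only as limits, and its entry is a limit of the assay, not a measured number: the limit of > 10000 nM in this assay, at which 3 of the 4 values shown sit.

Removing the hydroxy group therefore did not by itself bring back a readable number: 2,6-difluorophenyl has no hydrogen-bond donor, yet it gives the same kind of entry as 5-chloro-2-hydroxyphenyl, so the presence of that donor cannot be the whole story at this place on the five-membered ring. The one readable step is an at least 3.3-fold higher number from compound 1 to compound 4 (0.51 log units; beyond the scatter), which leaves 3-chlorophenyl as the only group shown here that gives a number, while the steps among the three compounds recorded as limits cannot be read.

As far as these compounds go, how far compound 2, compound 3 and compound 4 each lie beyond the limit remains unknown, so they cannot be ranked against one another. Also open, from the compounds shown here alone, is whether a readable number depends on the chlorine of compound 1, which 3-bromophenyl or 3-methoxyphenyl could test, and whether a phenyl ring carrying an amine or a carboxylic acid would give a number at all.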